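The source may report more compounds than this note shows. Statements on the series, on what has been measured and on what is new or still open speak of the compounds shown alone.

The measured compounds are compound 1 `CC1CCCN(c2nc(Cc3c(F)cccc3F)cc(=O)[nH]2)C1`, compound 2 `CC1CCN(c2nc(Cc3c(F)cccc3F)cc(=O)[nH]2)CC1` and compound 3 `Cc1c(C(C)c2c(F)cccc2F)nc(N2CCCC(C)C2)[nH]c1=O`.

In an ADME assay on MT4 cells (Homo sapiens) for cytotoxicity, read by MTT assay, with a stated time of 4 days (a lower number here means that less compound is tolerated, a higher number that more compound is tolerated), compound 1 gives > 78000 nM, which is a limit of the assay and not a number. Compound 2 gives > 78000 nM in this assay, again a limit. Compound 3 gives > 72000 nM in this assay, also a limit. The change from compound 1 to compound 2 is 4-methylpiperidin-1-yl in place of 3-methylpiperidin-1-yl on an aromatic carbon. Between these two there is a step that the two limits leave unreadable from compound 1 to compound 2. The difference between the core of compound 1 and the core of compound 3 is not broken down here.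

Compound 4 `Cc1c(C(C)c2c(F)cccc2F)nc(N2CCC(C)CC2)[nH]c1=O` has not yet been measured. It differs from compound 3 by 4-methylpiperidin-1-yl in place of 3-methylpiperidin-1-yl on an aromatic carbon. This is the same kind of change as that from compound 1 to compound 2, but the place differs: in compound 3 the carbon is meta to a large group and para to a methyl group, while in compound 1 it is meta to a group of 9 heavy atoms.

Compound 4 is expected to show a step of a number no higher from compound 3 to compound 4 (the limit leaves the size open) in this assay, resting on compound 1 and compound 2 both sitting at the limit of > 78000 nM in this assay, at which 2 of the 3 values shown sit, and on compound 3 sitting at the limit of > 72000 nM in this assay, at which 1 of the 3 values shown sits. Compound 4 is estimated at 72000 nM, expected between 40000 nM and 150000 nM.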

Compound 4, half-maximal cytotoxic concentration: 54000 nM
For compound 4 the middle estimate is 1.3-fold (0.12 log units) above the measured one, and the stated range covers the measured number.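

In this assay, the change from 3-methylpiperidin-1-yl to 4-methylpiperidin-1-yl on the core of compound 3 comes with an at least 1.3-fold lower number from compound 3 to compound 4 (0.12 log units; that floor lies within the scatter). Compound 3 gives > 72000 nM, which is a limit and not a number, so only a floor of that step is known. The same change on the core of compound 1 cannot be read, which leaves it unshown whether the step carries from one core to the other or fails to, because both compounds on that core stand at a limit: the limit of > 78000 nM in this assay, at which 2 of the 4 values shown sit.

As far as these compounds go, it remains open how this assay would respond on either core to a morpholin-4-yl group in place of the methylpiperidine, or to a piperidine carrying an amine or a carboxylic acid in place of the methyl group. Also open, from the compounds shown here alone, is the size of the step on the core of compound 1, which would need a number rather than a limit at both ends.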